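Trifluoromethyl in Place of Methyl on the Fused Core

The compounds below may be only part of what the source reports. "The series", "measured", "known", "first", "only" and "open" are said of these compounds alone.

Compound 1 `Cc1cc(Nc2nc(NCc3ccc(F)cc3F)nc3ccccc23)n[nH]1` gives 200 nM in an assay for inhibition of high affinity nerve growth factor receptor (Homo sapiens), read by HTRF, with a stated time of 30 min, in the presence of a further agent that is not named here; a lower number here means a stronger inhibitor, a higher number a weaker inhibitor.
Compound 2 `Cc1cc(Nc2nc(NCc3ccc(F)cc3F)nc3ccc(Cl)cc23)n[nH]1` gives 520 nM in this assay.
Compound 3 `Cc1ccc2nc(NCc3ccc(F)cc3F)nc(Nc3cc(C)[nH]n3)c2c1` gives 110 nM in this assay.

Compound 3 stands lowest of the three numbers. Its nearest neighbour is compound 1, and that step, a 1.8-fold lower number from compound 1 to compound 3 (0.26 log units; within the scatter), lies within the scatter, so the two cannot be ordered. Compound 2 lies furthest away, a 4.7-fold lower number from compound 2 to compound 3 (0.67 log units; beyond the scatter).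

Compound 4 `Cc1cc(Nc2nc(NCc3ccc(F)cc3F)nc3ccc(C(F)(F)F)cc23)n[nH]1` differs from compound 3 by one change: trifluoromethyl in place of methyl on an aromatic carbon. Among the measured compounds shown here, two measured steps bear on this place on the core. Hydrogen to chloro gave a 2.6-fold higher number from compound 1 to compound 2 (0.41 log units; beyond the scatter), and chloro to methyl gave a 4.7-fold lower number from compound 2 to compound 3 (0.67 log units; beyond the scatter). In both, the compound carrying chloro at this place gave the higher number, while methyl and hydrogen sat close together. Trifluoromethyl is a new group here, untested in this series, but it resembles chloro more than methyl in being a four-heavy-atom substituent carrying fluorine, so a higher number than compound 3 is expected, probably beyond the scatter, in the direction seen for compound 2.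

Compound 4 is therefore expected to give about 600 nM, within a range of 200 nM to 1800 nM. This estimate corresponds to an expected step of a 5.5-fold higher number from compound 3 to compound 4 (0.74 log units; beyond the scatter).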

Compound 4, half-maximal inhibitory concentration: 370 nM
For compound 4 the middle estimate is 1.6-fold (0.21 log units) above the measured one; the range from low to high includes it.
By their numbers in this assay, from the lowest: compounds 3, 1, 4 and 2 (each within the scatter of the next, the first and the last beyond it).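

In this assay, trifluoromethyl is the second group on this aromatic carbon of the shared core, after chloro, whose number stands clearly apart from that of methyl (a 3.4-fold higher number from compound 3 to compound 4 (0.53 log units; beyond the scatter)). It cannot be separated from chloro (a 1.4-fold lower number from compound 2 to compound 4 (0.15 log units; within the scatter)), nor can it be separated from hydrogen (a 1.9-fold higher number from compound 1 to compound 4 (0.27 log units; within the scatter)), even though chloro and hydrogen themselves lie beyond the scatter of each other. Compound 4 therefore sits in an intermediate place, and only its step from methyl can be read as a real change.

The compounds shown leave open how an amine, a methoxy group or a carboxylic acid on this carbon would compare with methyl, and whether the same order of groups would hold with another group in place of the difluorobenzyl amine. Nothing available here accounts for these differences.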